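The compounds below may be only part of what the source reports. "The series", "measured", "known", "first", "only" and "open" are said of these compounds alone.

Measured so far:
compound 1 `O=C1NC(=O)/C(=C\c2ccc(OCC(=O)N3N=C(c4ccccc4)CC3c3ccc(F)cc3)cc2)S1` — 1700 nM
compound 2 `O=C1NC(=O)/C(=C\c2ccc(OCC(=O)N3N=C(c4ccccc4)CC3c3ccc(F)cc3F)cc2)S1` — 2200 nM

The study concerns an assay on cells for inhibition of histone deacetylase 4 (Homo sapiens), read by fluorescence, with a stated time of 30 min; a lower number here means a stronger inhibitor, a higher number a weaker inhibitor. Compound 1 gives 1700 nM in this assay, the lower of the two numbers in hand; its nearest neighbour is compound 2, which gives 2200 nM. Among the compounds with values here, the single step between them, a 1.3-fold higher number from compound 1 to compound 2 (0.11 log units; within the scatter), is a fluoro in place of hydrogen on an aromatic carbon and stays within the scatter, so the two values cannot be ordered.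

Compound 3 `O=C1NC(=O)/C(=C\c2ccc(OCC(=O)N3N=C(c4ccc(F)cc4)CC3c3ccc(F)cc3)cc2)S1` has not yet been measured. It differs from compound 1 by fluoro in place of hydrogen on an aromatic carbon; cut one bond further out, this reads as phenyl to 4-fluorophenyl. Within the data shown here, the only measured step that bears on it is the one from compound 1 to compound 2, also a fluoro in place of hydrogen on an aromatic carbon, though on a different ring, and that step was within the scatter. On this single precedent no movement beyond the scatter is expected for compound 3 in this assay, in either direction. The step expected from compound 1 to compound 3 is therefore a 1.1-fold higher number from compound 1 to compound 3 (0.02 log units; within the scatter). Compound 3 is estimated at 1800 nM, with a range from 900 nM to 3600 nM.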

Compound 3, half-maximal inhibitory concentration: 1400 nM
Compound 3: middle estimate off by 1.3-fold (0.11 log units), on the high side; the range from low to high includes it.
By their numbers in this assay, from the lowest: compounds 3, 1 and 2 (each within the scatter of the next).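

In this assay, placing fluoro on an aromatic carbon of the phenyl ring, para to a large group, gives a 1.2-fold lower number from compound 1 to compound 3 (0.08 log units; within the scatter), so compound 1 and compound 3 cannot be ordered and this position tolerates phenyl to 4-fluorophenyl without a readable shift in the number. Together with a 1.3-fold higher number from compound 1 to compound 2 (0.11 log units; within the scatter), which lies on a different ring, this gives two separate places in these compounds where fluoro in place of hydrogen stays within the scatter, and neither step goes against the other. No measurement in hand gives a reason for this result or shows what the fluoro does at this position.

Left open is whether a different group at the same place, such as a chlorine, a methoxy, an amine or a carboxylic acid, would carry the number beyond the scatter in either direction, for fluoro is the only replacement for hydrogen shown here. Also open, as far as these compounds go, is what happens when the other ring carries only hydrogen in place of fluoro, as all three compounds keep at least one fluoro on that ring.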